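Propargyl in place of 2-bromobenzyl on the sulfur chain

This account rests on a few compounds, and the source may have more. Where it says the series, first, only, none or still open, it means among the compounds named here.

In a functional assay on MGC-803 cells (Homo sapiens) for inhibition, read by MTT assay, with a stated time of 72 h (on this read-out higher numbers stand for weaker inhibition and lower numbers for stronger inhibition), compound 1 (`Cc1cc(Nc2cc(-c3ccccc3)[nH]n2)n2nc(SCc3ccc(F)cc3)nc2n1`) gives 3270 nM while compound 2 (`Cc1cc(Nc2cc(-c3ccccc3)[nH]n2)n2nc(SCC(=O)c3ccccc3)nc2n1`) gives 2580 nM and compound 3 (`Cc1cc(Nc2cc(-c3ccccc3)[nH]n2)n2nc(SCc3ccccc3Br)nc2n1`) gives 3650 nM so compound 3 stands within the scatter of both others. Compound 4 (`C#CCSc1nc2nc(C)cc(Nc3cc(-c4ccccc4)[nH]n3)n2n1`) has ethynyl in place of 2-bromophenyl on a saturated chain carbon bound to a sulfur. Three measured steps at this place bear on it: a 1.3-fold lower number from compound 1 to compound 2 (0.10 log units; within the scatter) together with a 1.1-fold higher number from compound 1 to compound 3 (0.05 log units; within the scatter) and a 1.4-fold higher number from compound 2 to compound 3 (0.15 log units; within the scatter) and all lie within the scatter. Going by these compounds, each keeps a ring on the chain, so the loss of the ring is untested and the uncertainty is wide. In this assay the estimated step is a 1.1-fold higher number from compound 3 to compound 4 (0.04 log units; within the scatter) and none beyond the scatter is expected. Compound 4 is expected at 4000 nM with an estimated range from 1600 nM to 10000 nM as the working figure.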

Compound 4, half-maximal inhibitory concentration: 13400 nM
For compound 4 the middle estimate is 3.4-fold (0.53 log units) below the measured one, outside the stated range (above it).
By their numbers in this assay, from the lowest: compounds 2, 1 and 3 (each within the scatter of the next); then compound 4.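

In this assay, within the data shown here, the aryl and benzoyl groups on a saturated chain carbon bound to a sulfur could be exchanged within the scatter, but ethynyl is the first change to move the number beyond it, with a 3.7-fold higher number from compound 3 to compound 4 (0.56 log units; beyond the scatter). Against the other two groups the picture is the same, with a 5.2-fold higher number from compound 2 to compound 4 (0.72 log units; beyond the scatter) and a 4.1-fold higher number from compound 1 to compound 4 (0.61 log units; beyond the scatter). Nothing available explains this loss.

The change removes the ring and heavy atoms and adds a triple bond all at once, so these effects remain unseparated. A plain propyl or a cyclohexylmethyl group on the sulfur would help to pull them apart.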